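Solubility notes: aryl substituent swap on the shared core

The source may report more compounds than this note shows. Statements on the series, on what has been measured and on what is new or still open speak of the compounds shown alone.

Compound 1 `COc1ccc(-c2cc(-c3ccc(S(=O)(=O)NC4CC4)cc3)cnc2N)cn1`: > 100 ug/mL (a limit)
Compound 2 `COc1ccc(-c2cc(-c3ccc(-n4cncn4)cc3)cnc2N)cn1`: > 100 ug/mL (a limit)

In a physicochemical assay for solubility, read by nephelometry, measured as kinetic solubility, at pH 2 (a lower number here means a less soluble compound, a higher number a more soluble compound), compound 1 gives > 100 ug/mL, which is a limit of the assay. Compound 2 gives > 100 ug/mL, likewise a limit. Between them stands a step that the two limits leave unreadable from compound 1 to compound 2. Compound 3 `COc1ccc(-c2cc(-c3ccc(C(=O)O)cc3)cnc2N)cn1` differs from compound 2 by carboxy in place of 1H-1,2,4-triazol-1-yl on an aromatic carbon. Going by the values given here, no measured step settles the direction of this change, since both values sit at the limit of > 100 ug/mL in this assay, at which 2 of the 2 values shown sit. Compound 3 is therefore expected to remain close to that limit, the step of an at least 1.2-fold lower number from compound 2 to compound 3 (0.09 log units; that floor lies within the scatter) being estimated as small. For compound 3 the estimate is 80 ug/mL, within 20 ug/mL to 150 ug/mL.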

Compound 3, solubility: 12.5 ug/mL
Beside the measured number, compound 3's estimate is 6.4-fold (0.81 log units) above it, and the stated range ends above it.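

In this assay, the aromatic carbon para to a large group now proves sensitive to its substituent: carboxy in place of 1H-1,2,4-triazol-1-yl gives an at least 8.0-fold lower number from compound 2 to compound 3 (0.90 log units; beyond the scatter), and carboxy in place of cyclopropylsulfamoyl gives an at least 8.0-fold lower number from compound 1 to compound 3 (0.90 log units; beyond the scatter). Going by these compounds alone, both steps are floors, and compound 3 is the first compound here to give a number rather than a limit. The step between compound 1 and compound 2 cannot be read: the limit of > 100 ug/mL in this assay, at which 2 of the 3 values shown sit.

Going by these compounds, how far compound 1 and compound 2 lie past that limit remains open. Also open, on these data alone, is whether a methyl ester or an amine at this position would read nearer to compound 3 or to that limit.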